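A few compounds are considered here, and "the series" means these few. Any claim that something is new, unique, unknown or untested is made for them only; others in the source may bear on it.

Of the compounds shown here, two that share one core have been tested in an ADME assay on MT4 cells (Homo sapiens) for cytotoxicity, read by MTT assay; on this read-out higher numbers stand for lower toxicity in this test and lower numbers for higher toxicity in this test. Among the compounds with values here, compound 1 `CCCCCOc1ccc(C(=O)N(C(=S)OCCN2C(=O)c3ccccc3C2=O)c2ccc(F)cc2)cc1` is the first of them. In this assay compound 1 gives > 100000 nM, which is a limit of the assay and not a number. This is the limit of > 100000 nM in this assay, at which 1 of the 2 values shown sits. Compound 2 `O=C1c2ccccc2C(=O)N1CCOC(=S)N(C(=O)c1c(F)cccc1F)c1ccc(Cl)cc1` is the second. In this assay, within the data shown here, compound 2 gives 39000 nM, the only number among the two results. Compound 3 `O=C1c2ccccc2C(=O)N1CCOC(=S)N(C(=O)c1ccc([N+](=O)[O-])cc1Cl)c1ccc(Cl)cc1` has not yet been tested. It differs from compound 2 in one place: 2-chloro-4-nitrophenyl in place of 2,6-difluorophenyl on a carbonyl carbon. Among the measured compounds shown here, no two measured compounds differ in a single place, so no measured step shows how a change of this kind moves the result in this assay. The expectation for compound 3 therefore rests on compound 2 alone. The step is expected to be small, a 1.1-fold lower number from compound 2 to compound 3 (0.05 log units; within the scatter), with no direction that stands out beyond the scatter. Compound 3 is thus estimated at 35000 nM, with a range from 12000 nM to 100000 nM.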

Compound 3, half-maximal cytotoxic concentration: 19000 nM
The estimate for compound 3 lay 1.8-fold (0.27 log units) above the measured number; the measured number falls inside the stated range.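

In this assay, putting 2-chloro-4-nitrophenyl in place of 2,6-difluorophenyl on a carbonyl carbon gives a 2.1-fold lower number from compound 2 to compound 3 (0.31 log units; beyond the scatter). Within the data shown here, this is the first single-place step available, and it shows that the result responds to a change at this position, even though the whole group is exchanged and the core stays the same. The step is modest but lies beyond the usual scatter, and since a lower number stands for higher toxicity in this test, compound 3 is the more toxic of this pair.

A single pair cannot show whether the chlorine, the nitro group or the loss of the two fluorines accounts for the step, nor how a phenyl ring carrying an amine or a carboxylic acid would read at this position. Compound 1 differs from the other two in more than one place and its result is a limit, not a number, so it adds no measured step to this comparison: the limit of > 100000 nM in this assay, at which 1 of the 3 values shown sits.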